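The source may hold more compounds than are shown below. What is called first, only, known or untested is meant among the compounds shown, and "the series" means these compounds.

Going by the values given here, compound 2 `COc1ccc2c(=O)c(/C=C/C(=O)Nc3ccc(Cl)cc3)coc2c1` gives the lower of the two numbers so far in an ADME assay on HepG2 2.2.15 cells (Homo sapiens) for cytotoxicity, read by MTT assay, with stated times of 48 h and 9 days (a higher number here means that more compound is tolerated, a lower number that less compound is tolerated), at 272000 nM, while compound 1 `COc1ccc2c(=O)c(/C=C/C(=O)Nc3cccc(C)c3)coc2c1` gives 554000 nM. Among the compounds with values here, the single measured step, a 2.0-fold lower number from compound 1 to compound 2 (0.31 log units; beyond the scatter), is a swap of the group on the amide-type nitrogen. Compound 3 `CCOc1ccc(NC(=O)/C=C/c2coc3cc(OC)ccc3c2=O)cc1` differs from compound 2 by ethoxy in place of chloro on an aromatic carbon. Within the data shown here, no measured step exchanges chloro for ethoxy, so the only guide is the size of that one swap. A step of about that size in either direction, or none beyond the scatter, is expected for a 1.3-fold higher number from compound 2 to compound 3 (0.11 log units; within the scatter). Compound 3 is estimated at 350000 nM, with a range of 150000 nM to 800000 nM.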

Compound 3, half-maximal cytotoxic concentration: 460000 nM
The estimate for compound 3 lay 1.3-fold (0.12 log units) below the measured number; low and high end bracket the measured number.
By their numbers in this assay, from the lowest: compounds 2, 3 and 1 (each within the scatter of the next, the first and the last beyond it).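

In this assay, ethoxy in place of chloro on this aromatic carbon gives a 1.7-fold higher number from compound 2 to compound 3 (0.23 log units; within the scatter), so this exchange does not move the number beyond the scatter. Going by these compounds alone, the 4-ethoxyphenyl group in place of 3-methylphenyl on the amide-type nitrogen gives a 1.2-fold lower number from compound 1 to compound 3 (0.08 log units; within the scatter), so compound 1 and compound 2 remain the only pair here separated beyond the scatter. No supporting measurement bears on these differences.

Going by these compounds, whether an amine, a carboxylic acid or a longer alkoxy chain on this aromatic carbon would shift the number further remains open. Changes to the shared core also remain open.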